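The source may hold more compounds than are shown below. What is called first, only, known or untested is meant among the compounds shown, and "the series" means these compounds.

Measured in an ADME assay on the whole organism (Mus musculus, strain CD-1) for pharmacokinetics, at a dose of 10 mg/kg by the oral route; on this read-out lower numbers stand for lower exposure and higher numbers for higher exposure at the dose given:
- compound 1 `CCCOc1cc([C@](O)(CCN(C)C)[C@@H](c2cc3cc(Br)ccc3nc2OC)c2ccnc(OC)c2OC)cc(OC)n1`: 10900 ng.h/mL
- compound 2 `COc1cc([C@](O)(CCN(C)C)[C@@H](c2cc3cc(C#N)ccc3nc2OC)c2cccc(C)c2F)cc(OC(F)F)n1`: 8600 ng.h/mL
- compound 3 `COc1cc([C@](O)(CCN(C)C)[C@@H](c2cc3cc(C#N)ccc3nc2OC)c2ccnc(OC)c2OC)cc(OC(F)F)n1`: 3000 ng.h/mL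

Among these three, compound 2 at 8600 ng.h/mL lies within the scatter of compound 1 and well clear of compound 3. Next is compound 4 `CCSc1cc([C@](O)(CCN(C)C)[C@@H](c2cc3cc(C#N)ccc3nc2OC)c2cccc(C)c2F)cc(SCC)n1`, with this change: a group of 12 heavy atoms (9 carbon, 1 nitrogen, 2 sulfur; one six-membered aromatic ring with 1 hetero atom) in place of a group of 12 heavy atoms (7 carbon, 1 nitrogen, 2 oxygen, 2 fluorine; one six-membered aromatic ring with 1 hetero atom), on a saturated chain carbon bound to an oxygen on a saturated carbon and two saturated chain carbons.

Among the measured compounds shown here, no step at this place has been measured. For the measured compounds named here, the only step available, a 2.9-fold lower number from compound 2 to compound 3 (0.46 log units; beyond the scatter), concerns a different group, so it offers a rough size and no firm direction. A modest fall in this assay is tentatively expected. The expected change is a 2.5-fold lower number from compound 2 to compound 4 (0.39 log units; beyond the scatter). For compound 4 the estimated value is 3500 ng.h/mL, with an expected range of 1000 ng.h/mL to 10000 ng.h/mL.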

Compound 4, area under the concentration-time curve: 4000 ng.h/mL
Beside the measured number, compound 4's estimate is 1.1-fold (0.06 log units) below it; measured number inside the range.
By their numbers in this assay, from the lowest: compounds 3 and 4 (each within the scatter of the next); then compounds 2 and 1 (each within the scatter of the next).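

Measured in this assay the change on this saturated chain carbon gives a 2.2-fold lower number from compound 2 to compound 4 (0.33 log units; beyond the scatter) and so shows that this place affects exposure. The step lies beyond the scatter even though the entering group keeps the six-membered aromatic ring with 1 hetero atom and the same donor and acceptor counts as the group it replaces. Nothing available explains this step.

As far as these compounds go, whether the 2 sulfur atoms or the loss of the 2 fluorine atoms carries the step stays open, as both change together. From the compounds shown here alone, how a group bearing an amine or a carboxylic acid would read at this place also stays open.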